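This account rests on a few compounds, and the source may have more. Where it says the series, first, only, none or still open, it means among the compounds named here.

In a functional assay on the whole organism with Mus musculus as the target, in the maximal electroshock model (on this read-out lower numbers stand for an effect already at smaller amounts and higher numbers for an effect only at larger amounts of compound), compound 1 (`C[C@@H](NCc1ccc(OCc2ccccc2)cc1)C(N)=O`) gives 17.1 mg/kg, compound 2 (`CNC(=O)[C@@H](C)NCc1ccc(OCc2ccccc2)cc1`) gives 7 mg/kg and compound 3 (`CNC(=O)[C@@H](CO)NCc1ccc(OCc2ccccc2)cc1`) gives 22.8 mg/kg. Compound 3 therefore cannot be told apart from one of its relatives but stands clear of the other: the numbers show a 1.3-fold higher number from compound 1 to compound 3 (0.12 log units; within the scatter), and also a 3.3-fold higher number from compound 2 to compound 3 (0.51 log units; beyond the scatter).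

Compound 4 (`CNC(=O)[C@@H](CO)NCc1ccc(OCc2ccccc2F)cc1`) differs from compound 3 in one place: fluoro in place of hydrogen on an aromatic carbon. This fluoro in place of hydrogen on an aromatic carbon turns benzyl into 2-fluorobenzyl. Within the data shown here, no measured step touches an aromatic carbon, so the data hold no direct precedent. The two single-place steps on record, a 2.4-fold lower number from compound 1 to compound 2 (0.39 log units; beyond the scatter) and a 3.3-fold higher number from compound 2 to compound 3 (0.51 log units; beyond the scatter), concern an amide-type nitrogen and a saturated chain carbon, and they serve only as a guide to size. On these data alone, both were modest, so no step beyond the scatter is expected here, and the direction stays open.

The estimate for compound 4 is 17 mg/kg, with an expected range from 7 mg/kg to 38 mg/kg. This expectation amounts to a 1.3-fold lower number from compound 3 to compound 4 (0.13 log units; within the scatter).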

Compound 4, dose for half-maximal effect: 19.8 mg/kg
The estimate for compound 4 lay 1.2-fold (0.07 log units) below the measured number, within the range that was stated.
By their numbers in this assay, from the lowest: compound 2; then compounds 1, 4 and 3 (each within the scatter of the next).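

Among these compounds, the change from benzyl to 2-fluorobenzyl is the first step here to touch an aromatic carbon, and in this assay it gives a 1.2-fold lower number from compound 3 to compound 4 (0.06 log units; within the scatter). On the background of compound 3, this aromatic carbon therefore takes a single fluorine without a readable shift, whereas the earlier single-place changes on the amide-type nitrogen and the saturated chain carbon gave a 2.4-fold lower number from compound 1 to compound 2 (0.39 log units; beyond the scatter) and a 3.3-fold higher number from compound 2 to compound 3 (0.51 log units; beyond the scatter), both beyond the scatter. No measurement on record bears on why the fluoro step stays this small.

On these data alone, it remains open whether a chlorine, a methoxy group or a trifluoromethyl group on the same aromatic carbon would also leave the number unmoved. As far as these compounds go, it is equally open whether fluoro would behave the same way on compound 2, which lacks the hydroxy group of compound 3.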